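Swapping Chloro for Methyl on the Best Furan Hydroxamate

The source may report more compounds than this note shows. Statements on the series, on what has been measured and on what is new or still open speak of the compounds shown alone.

Measured in a functional assay on HepG2 cells (Homo sapiens) for antiproliferative activity, read by MTT assay, with a stated time of 48 h; a lower number here means a stronger inhibitor, a higher number a weaker inhibitor:
- Compound 1 `COc1cc(/C=C/c2ccc(C(=O)NO)o2)ccc1OCc1ccccc1` gives 30900 nM
- Compound 2 `O=C(/C=C/c1ccc(/C=C/C(=O)c2cccc(Cl)c2)o1)NO` gives 54500 nM
- Compound 3 `O=C(/C=C/c1ccc(/C=C/C(=O)c2ccc(Cl)cc2)o1)NO` gives 6740 nM

Compound 3 has the lowest number of the three. Compound 4 `Cc1ccc(C(=O)/C=C/c2ccc(/C=C/C(=O)NO)o2)cc1` departs from it at one place: methyl in place of chloro on an aromatic carbon, the change from 4-chlorophenyl to 4-methylphenyl. Among the measured compounds shown here, one measured step bears on this, and only indirectly: an 8.1-fold lower number from compound 2 to compound 3 (0.91 log units; beyond the scatter). For the measured compounds named here, that modest step moves the chloro group and does not replace it, so no measured pair shows this swap. Only a small change is therefore expected in this assay, with a slight rise at most. The expected step is a 1.3-fold higher number from compound 3 to compound 4 (0.13 log units; within the scatter), probably within the scatter. For compound 4 the estimate is 9000 nM, with an expected range of 3500 nM to 25000 nM.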

Compound 4, half-maximal inhibitory concentration: 16000 nM
Compound 4: middle estimate off by 1.8-fold (0.25 log units), on the low side; the range from low to high includes it.
By their numbers in this assay, from the lowest: compound 3; then compounds 4, 1 and 2 (each within the scatter of the next, the first and the last beyond it).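

In this assay the chloro group of compound 3 is not freely exchangeable for methyl: the swap gives a 2.4-fold higher number from compound 3 to compound 4 (0.38 log units; beyond the scatter) and so the number at this position depends on which group sits there, not only on where it sits. The 4-methylphenyl group still compares well with the 3-chlorophenyl group, with a 3.4-fold lower number from compound 2 to compound 4 (0.53 log units; beyond the scatter) in this assay. No measurement given here accounts for either step.

The compounds shown hold only chloro and methyl at this position. Going by these compounds, how fluoro, methoxy or an amine would compare with chloro stays open.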